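The compounds below may be only part of what the source reports. "The series", "measured", "known", "first", "only" and "open" are said of these compounds alone.

Compound 1 `CCc1ccc(NC2=CC(=O)c3c(nc4n3[C@H]3OC[C@@H](O)[C@H]3OC4)C2=O)cc1`: 8990 nM
Compound 2 `Cc1ccc(NC2=CC(=O)c3c(nc4n3[C@H]3OC[C@@H](O)[C@H]3OC4)C2=O)cc1`: > 4000 nM
Compound 3 `O=C1C(N2CCCCC2)=CC(=O)c2c1nc1n2[C@H]2OC[C@@H](O)[C@H]2OC1`: > 8000 nM

In a functional assay on MCF7 cells (Homo sapiens) for inhibition, read by sulforhodamine B assay (on this read-out higher numbers stand for weaker inhibition and lower numbers for stronger inhibition), compound 1 gives a number, 8990 nM. For compound 2 the read-out is only a limit, > 4000 nM. For compound 3 it is likewise only a limit, > 8000 nM, so compound 3 stands without a number of its own, and one further value shown is also a limit. Compound 4 `O=C1C(NC2CCCCC2)=CC(=O)c2c1nc1n2[C@H]2OC[C@@H](O)[C@H]2OC1` differs from compound 3 by cyclohexylamino in place of piperidin-1-yl on a double-bonded ring carbon. The steps that touch compound 3 are a step that the limit leaves unreadable from compound 1 to compound 3 and a step that the two limits leave unreadable from compound 2 to compound 3, neither of readable size. Among the measured compounds shown here, no step of known size therefore bears on the change. Compound 4 is expected to give about 10000 nM, between 3000 nM and 40000 nM. The step this estimate means, a step that the limit leaves unreadable from compound 3 to compound 4, is expected to stay within the scatter.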

Compound 4, half-maximal inhibitory concentration: > 16000 nM
Compound 4 ended at the assay's limit (the forecaster's own chance of this, stated with the estimate: 60%); middle value at least 1.6-fold (0.20 log units) away from the limit.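

In this assay compound 4 gives > 16000 nM, which is a limit of the assay and not a number. With cyclohexyl in place of 4-ethylphenyl on the amine nitrogen, the one readable comparison is an at least 1.7-fold higher number from compound 1 to compound 4 (0.25 log units; that floor lies within the scatter), so this change is not shown to weaken inhibition beyond the usual scatter. The other new steps cannot be read, which leaves cyclohexylamino and piperidin-1-yl unranked at this double-bonded ring carbon. Going by these compounds, how far compound 4 really lies from compound 1 remains open. Also open, on these data alone, is how a benzyl or 4-methoxyphenyl group on the amine nitrogen would read.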